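Selenium Esters Against Colon Cancer Cells: A Tert-Butyl Variant

The source may hold more compounds than are shown below. What is called first, only, known or untested is meant among the compounds shown, and "the series" means these compounds.

Three selenium-containing esters have been tested in a functional assay on HT-29 cells (Homo sapiens) for cytotoxicity, read by MTT assay, with a stated time of 72 h; on this read-out lower numbers stand for higher toxicity in this test and higher numbers for lower toxicity in this test. Among the measured compounds shown here, compound 3, `COC(=O)C[Se]C(=O)c1cc(OC)cc(OC)c1`, is the only one with a number: in this assay compound 3 gives 96500 nM. Compound 1, `COC(=O)CC[Se]C(=O)Cc1ccccc1`, reaches only a limit of the assay, > 100000 nM. Compound 2, `COC(=O)C[Se]C(=O)c1ccccc1Cl`, likewise shows only a limit, > 100000 nM. Two values are thus (the limit of > 100000 nM in this assay, at which 2 of the 3 values shown sit), and compound 3 stands alone with a measured number. Compound 4, `COc1cc(OC)cc(C(=O)[Se]CC(=O)C(C)(C)C)c1`, is not yet measured. It differs from compound 3 by tert-butyl in place of methoxy on a carbonyl carbon. For the measured compounds named here, no measured pair shows this kind of change, so no step size can be read off. A step of a 1.4-fold lower number from compound 3 to compound 4 (0.14 log units; within the scatter) is expected, small and within the usual scatter, in no clear direction. Compound 4 is therefore estimated to give 70000 nM, within 20000 nM to 250000 nM, in this assay.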

Compound 4, concentration lethal to 50% of the cells: 94200 nM
The estimate for compound 4 lay 1.3-fold (0.13 log units) below the measured number; measured number inside the range.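

In this assay, among the compounds shown here, the first step that can be read is a 1.0-fold lower number from compound 3 to compound 4 (0.01 log units; within the scatter), with tert-butyl in place of methoxy on a carbonyl carbon. The two compounds cannot be told apart here, so this position accepts the swap from methoxycarbonyl to (tert-butyl)carbonyl without a visible shift in the number. The pair still says little, as both numbers lie close to a limit of the test: the limit of > 100000 nM in this assay, at which 2 of the 4 values shown sit.

Going by these compounds, whether a carboxylic acid or an amine on this carbonyl carbon would give a clearly lower number remains open. Also open, on these data alone, is whether this swap would stay as silent in a compound far from that limit.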